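The compounds below may be only part of what the source reports. "The series", "measured", "known", "first", "only" and "open" are said of these compounds alone.

In an ADME assay on MDBK cells (Bos taurus) for cytotoxicity (on this read-out higher numbers stand for lower toxicity in this test and lower numbers for higher toxicity in this test), compound 1 `COc1cccc(Cn2ccc3nc(-c4ccccc4)nc-3c2)c1` gives > 100000 nM, which is a limit of the assay and not a number. Compound 2 `Fc1ccccc1Cn1ccc2nc(-c3ccccc3)nc-2c1` likewise gives only a limit, > 100000 nM. Compound 3 `Fc1cccc(Cn2ccc3nc(-c4ccccc4)nc-3c2)c1` also stands at a limit, > 100000 nM, so it cannot be ranked against the other two. Compound 4 `Brc1ccc(Cn2ccc3nc(-c4ccccc4)nc-3c2)cc1` carries 4-bromophenyl in place of 3-fluorophenyl on a saturated chain carbon bound to an aromatic nitrogen. The measured steps that bear on this change are a step that the two limits leave unreadable from compound 2 to compound 3, a step that the two limits leave unreadable from compound 1 to compound 2 and a step that the two limits leave unreadable from compound 1 to compound 3. None has a readable size, and the whole record is the limit of > 100000 nM in this assay, at which 3 of the 3 values shown sit. The expected step is a number no higher from compound 3 to compound 4 (the limit leaves the size open), with no change beyond the scatter expected and a further limit as the likeliest result. Compound 4 is estimated at 100000 nM, with an expected range of 50000 nM to 200000 nM.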

Compound 4, half-maximal cytotoxic concentration: 83000 nM
Compound 4: the middle estimate sits 1.2-fold (0.08 log units) above what was measured, within the range that was stated.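

4-bromophenyl is the first group at this place to give an actual number rather than a limit in this assay, yet the steps remain small or uncertain: an at least 1.2-fold lower number from compound 3 to compound 4 (0.08 log units; that floor lies within the scatter) and an at least 1.2-fold lower number from compound 2 to compound 4 (0.08 log units; that floor lies within the scatter) and an at least 1.2-fold lower number from compound 1 to compound 4 (0.08 log units; that floor lies within the scatter) are all only floors, so the true sizes stay unknown. The earlier steps shown here cannot be read at all. Nearly the whole record still sits at one limit: the limit of > 100000 nM in this assay, at which 3 of the 4 values shown sit.

From the compounds shown here alone, how far the number could fall at this place stays open. An amine or a carboxylic acid in place of the substituted phenyl might answer that.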